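Enlarging the piperazine substituent in an adenosine receptor series

The source may report more compounds than this note shows. Statements on the series, on what has been measured and on what is new or still open speak of the compounds shown alone.

Compound 1 `CCCn1c(=O)[nH]c2nc(-c3ccc(S(=O)(=O)N4CCN(C)CC4)cc3)[nH]c2c1=O` is a xanthine-like core carrying a phenyl sulfonamide linked to a piperazine whose amine nitrogen bears a methyl. In an assay on CHO cells for displacement of a labelled ligand from adenosine receptor A3 (Homo sapiens), read by scintillation counting, with a stated time of 45 min, tested at 1 uM, in the presence of a further agent that is not named here (a higher number here means more inhibition at the concentration tested (going by the name of the read-out), a lower number less inhibition), compound 1 gives 7%, the lowest of the three numbers shown. Compound 2 `CCCn1c(=O)c2[nH]c(-c3ccc(S(=O)(=O)N4CCN(c5ccc(Cl)cc5)CC4)cc3)nc2n(CC)c1=O` gives 28% and compound 3 `CCCn1c(=O)c2[nH]c(-c3ccc(S(=O)(=O)N4CCN(c5ccc(Cl)cc5)CC4)cc3)nc2n(C)c1=O` gives 39%; both carry a 4-chlorophenyl on the piperazine nitrogen and also differ from compound 1 in the core, so neither forms a single-change comparison with it. Within the data shown here, the one clean step, a number 11 percentage points higher from compound 2 to compound 3 (beyond the scatter), concerns the core nitrogen, not the piperazine, and therefore does not speak directly to the change considered here.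

Compound 4 `CCCn1c(=O)[nH]c2nc(-c3ccc(S(=O)(=O)N4CCN(C(C)c5ccccc5)CC4)cc3)[nH]c2c1=O` arises from compound 1 by 1-phenylethyl in place of methyl on an amine nitrogen in a ring. Among the measured compounds shown here, no measured step covers this exact change. Compounds 2 and 3 show that an aromatic group on that nitrogen can accompany higher numbers, but the core differences leave that reading uncertain. A modest rise is therefore expected, as an estimate of a number 13 percentage points higher from compound 1 to compound 4 (beyond the scatter). Compound 4 is estimated to give 20%, with a likely range from 5% to 40%.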

Compound 4, a percentage reported as inhibition, at one concentration (the size of the read-out at that concentration, not a potency): 0%
Compound 4: the middle estimate sits 20 percentage points above what was measured; measured number outside the range, below it.
By their numbers in this assay, from the lowest: compounds 4 and 1 (each within the scatter of the next); then compound 2; then compound 3.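

Among these compounds, on the core of compound 1, this is the only direct reading of a larger group on the amine nitrogen in the ring: a number 7 percentage points lower from compound 1 to compound 4 (within the scatter) in this assay. Replacing methyl, a single carbon, with 1-phenylethyl, which brings eight heavy atoms and a six-membered aromatic ring, therefore gives no step beyond the scatter. On this core, then, an aromatic ring at this position does not by itself bring a higher number, and any link between the aryl substituent and the higher numbers of compound 2 and compound 3 now looks weaker, although their different cores keep them out of any direct comparison. Nothing available here gives a reason for this result.

Still open, on these data alone, is whether 4-chlorophenyl on this same nitrogen would change the number on the core of compound 1, which would separate the effect of that group from the effect of the core. As far as these compounds go, it is equally open whether a plain phenyl or a benzyl group, which lacks the branching methyl of 1-phenylethyl, would read differently from compound 4 at this position.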